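The source may report more compounds than this note shows. Statements on the series, on what has been measured and on what is new or still open speak of the compounds shown alone.

For the measured compounds named here, in a functional assay on SK-BR-3 cells (Homo sapiens) for antiproliferative activity, read by MTT assay, with a stated time of 72 h (a higher number here means a weaker inhibitor, a lower number a stronger inhibitor), compound 1 `Cc1cc(NCCN2CCN(C)CC2)nc2ccc(NC(=O)c3ccc(Cl)c(Cl)c3)cc12` gives 2690 nM, the lowest of the three numbers so far. Going by the values given here, compound 2 `CCc1ccc(C(=O)Nc2ccc3nc(N4CCN(CC)CC4)cc(C)c3c2)cc1` gives 9850 nM, and compound 3 `CCN1CCN(c2cc(C)c3cc(NC(=O)c4ccccc4)ccc3n2)CC1` gives 18400 nM; the single counted step between them, a 1.9-fold higher number from compound 2 to compound 3 (0.27 log units; within the scatter), stays within the scatter. Compound 4 `CCNc1cc(C)c2cc(NC(=O)c3ccc(Cl)c(Cl)c3)ccc2n1` differs from compound 1 in one place: hydrogen in place of 4-methylpiperazin-1-yl on a saturated chain carbon, two bonds along the chain from a nitrogen on an aromatic ring. Among the compounds with values here, no measured step covers a change of this kind, as the only counted step concerns a group on an aromatic carbon, so the expectation rests on the change alone. The step of a 3.0-fold higher number from compound 1 to compound 4 (0.47 log units; beyond the scatter) is expected to be modest, toward a weaker inhibitor, and not firmly beyond the scatter. Compound 4 is therefore estimated at 8000 nM, within a range from 2500 nM to 25000 nM.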

Compound 4, half-maximal inhibitory concentration: 28200 nM
The estimate for compound 4 lay 3.5-fold (0.55 log units) below the measured number; measured number outside the range, above it.
By their numbers in this assay, from the lowest: compound 1; then compounds 2, 3 and 4 (each within the scatter of the next, the first and the last beyond it).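

In this assay, for the compounds shown here, going from (2-(4-methylpiperazin-1-yl)ethyl)amino to ethylamino gives a 10-fold higher number from compound 1 to compound 4 (1.02 log units; beyond the scatter), a large step, whereas the only earlier step, on an aromatic carbon, stayed within the scatter. This position is therefore the first shown where one change clearly moves the number, and losing the 4-methylpiperazin-1-yl group goes with a weaker inhibitor. No measurement shown here explains this step. Still open, going by these compounds, is whether a 2-(dimethylamino)ethyl group, a simpler amine in the same place, or a longer chain carrying 4-methylpiperazin-1-yl would keep the number of compound 1.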